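This account rests on a few compounds, and the source may have more. Where it says the series, first, only, none or still open, it means among the compounds named here.

Working notes on the series. Compound 3 `COc1ccc(C(=O)/C=C/c2cc(-c3cc(OC)c(OC)c(OC)c3)n[nH]2)cc1OC` gives 7380 nM in a functional assay on M14 cells (Homo sapiens) for inhibition, read by sulforhodamine B assay, with a stated time of 48 h (a higher number here means that more compound is tolerated, a lower number that less compound is tolerated), the lowest of the two numbers shown, and compound 2 `COc1ccc(-c2cc(/C=C/C(=O)c3cc(OC)c(OC)c(OC)c3)[nH]n2)cc1OC` gives 7540 nM, a pair within the scatter. Compound 1 `COc1cc(-c2cc(/C=C/C(=O)c3ccc(Cl)c(Cl)c3)[nH]n2)cc(OC)c1OC` sits at a limit of this assay, > 100000 nM (the limit of > 100000 nM in this assay, at which 1 of the 3 values shown sits). Within the data shown here, the one measured step, an at least 13-fold lower number from compound 1 to compound 3 (1.13 log units; beyond the scatter), changed the ring on the carbonyl carbon. Compound 4 `COc1cc(C(=O)/C=C/c2cc(-c3cc(OC)c(OC)c(OC)c3)n[nH]2)cc(OC)c1OC` differs from compound 3 by methoxy in place of hydrogen on an aromatic carbon. Among the measured compounds shown here, no measured step touches this position directly; the step from compound 1 to compound 3 shows the ring on the carbonyl carbon matters, but a single methoxy added there is a smaller change. A step of about a 1.2-fold lower number from compound 3 to compound 4 (0.09 log units; within the scatter) is expected, within the scatter. Compound 4 is estimated at 6000 nM, between 2000 nM and 20000 nM.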

Compound 4, concentration lethal to 50% of the cells: 6130 nM
Beside the measured number, compound 4's estimate is 1.0-fold (0.01 log units) below it; low and high end bracket the measured number.
By their numbers in this assay, from the lowest: compounds 4, 3 and 2 (each within the scatter of the next). At a limit, above all of these: compound 1.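

In this assay, methoxy in place of hydrogen on an aromatic carbon, ortho to a methoxy group, gives a 1.2-fold lower number from compound 3 to compound 4 (0.08 log units; within the scatter), and likewise a 1.2-fold lower number from compound 2 to compound 4 (0.09 log units; within the scatter). The earlier step showed only that exchanging the substituents on the ring on the carbonyl carbon matters; these steps show that this single position accepts methoxy with the number staying within the scatter. No measured property on hand bears on these steps.

On these data alone, whether an amine, a carboxylic acid or a longer chain such as butoxy would be accepted at this position remains open.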